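This account rests on a few compounds, and the source may have more. Where it says the series, first, only, none or still open, it means among the compounds named here.

Compound 1 `CCOC(=O)C1=C(C)NC(C)=C(C(=O)OCC)C1c1csc(-c2ccc(Cl)cc2)n1` gives 3650 nM in an assay on isolated protein for antagonist activity at Voltage-dependent L-type calcium channel subunit alpha-1C (Cavia porcellus), with a stated time of 15 min; a lower number here means a stronger inhibitor, a higher number a weaker inhibitor.
Compound 2 `CC1=C(C(=O)OC2CCCCC2)C(c2csc(-c3ccc(Cl)cc3)n2)C(C(=O)OC2CCCCC2)=C(C)N1` gives 11000 nM in this assay.
Compound 3 `COC(=O)C1=C(C)NC(C)=C(C(=O)OCc2ccccc2)C1c1csc(-c2ccc(Cl)cc2)n1` gives 64900 nM in this assay.

Among the compounds with values here, of the three compounds measured so far, compound 1 has the lowest number in this assay. Compound 2, with the same core and two cyclohexyl esters, stands nearest to it, and its higher number lies beyond the scatter of repeated measurements. Compound 3, carrying a methyl ester on one side and a benzyl ester on the other, is the furthest away, and its number is higher still. Within this small set the ethyl diester therefore sits at the strong end, and both compounds with larger ester groups give weaker inhibition.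

Compound 4 `CCOC(=O)C1=C(C)NC(C)=C(C(=O)OCCc2ccccc2)C1c1csc(-c2ccc(Cl)cc2)n1` has not yet been measured in this assay. It differs from compound 1 in one place: phenyl in place of hydrogen on a saturated chain carbon, two bonds along the chain from an oxygen next to a carbonyl group. Given that compound 2 gives 11000 nM and compound 3 gives 64900 nM against the lower number of compound 1, a move toward a larger ester is expected to raise the number, by a step that is small but beyond the scatter. That expected step reads a 2.5-fold higher number from compound 1 to compound 4 (0.39 log units; beyond the scatter). Compound 4 is accordingly estimated at 9000 nM, with a range from 3000 nM to 30000 nM.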

Compound 4, half-maximal inhibitory concentration: 12100 nM
Beside the measured number, compound 4's estimate is 1.3-fold (0.13 log units) below it; low and high end bracket the measured number.
By their numbers in this assay, from the lowest: compound 1; then compounds 2 and 4 (each within the scatter of the next); then compound 3.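

Within the data shown here, this is the first change in the set made at one place alone: with the rest of the molecule held fixed, ethyl to phenethyl gives a 3.3-fold higher number from compound 1 to compound 4 (0.52 log units; beyond the scatter) in this assay. The position therefore accepts a phenyl on the ester chain with a modest loss rather than a complete one, and compound 4 still gives a measured value of 12100 nM. Nothing available on these compounds gives a reason for the rise.

The compounds shown do not separate the effect of the phenyl ring from that of the extended chain, and a propyl or butyl ester, which carries a chain but no ring, would be needed to tell the two apart. They also leave open how this position responds to an amine or a carboxylic acid at the end of the chain, and whether a chloro or methoxy group on the added phenyl would move the number in either direction.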